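Removing a Trifluoromethyl Group: What Remains of the Inhibition?

A few compounds are considered here, and "the series" means these few. Any claim that something is new, unique, unknown or untested is made for them only; others in the source may bear on it.

Compound 1, `Nc1nc(N)nc(-c2ccccc2[N+](=O)[O-])n1`, gives 11% in a functional assay on the whole organism with Rattus norvegicus as the target, at a dose of 20 mg/kg by the intraperitoneal route; a higher number here means more inhibition at the dose given (going by the name of the read-out), a lower number less inhibition.
Compound 2, `Nc1nc(N)nc(-c2cc(C(F)(F)F)ccc2Cl)n1`, gives 51% in this assay.

Among these two numbers compound 2 stands highest; its only neighbour is compound 1, which lies well below it, a gap beyond the usual scatter of repeated measurements. The next compound, compound 3, `Nc1nc(N)nc(-c2ccccc2Cl)n1`, differs from compound 2 in a single place: hydrogen in place of trifluoromethyl on an aromatic carbon. The trifluoromethyl leaves and a hydrogen enters, para to a chloro group. Going by the values given here, no measured pair shows this particular change, so its size cannot be read off the data; compound 1 and compound 2 differ in too many places to help. A moderate loss in this assay is expected, a number 21 percentage points lower from compound 2 to compound 3 (beyond the scatter), with wide uncertainty in either direction. Compound 3 is therefore estimated at 30%, in a range from 8% to 55%.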

Compound 3, a percentage reported as inhibition, in the whole organism at one dose (the size of the read-out at that dose, not a potency): 36%
Compound 3: the middle estimate sits 6 percentage points below what was measured; the measured number falls inside the stated range.
By their numbers in this assay, from the lowest: compound 1; then compound 3; then compound 2.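

Taking away the trifluoromethyl group, para to a chloro group, gives a real but partial loss in this assay with a number 15 percentage points lower from compound 2 to compound 3 (beyond the scatter) and compound 3 still at 36%, so much of the inhibition seen here does not depend on that group. Compound 3 also provides the single-place comparison that compound 1 and compound 2 could not offer: with chloro in place of nitro on an aromatic carbon, the change is a number 25 percentage points higher from compound 1 to compound 3 (beyond the scatter) and the gain exceeds the loss from removing trifluoromethyl. No measurement shown explains either step.

The compounds shown leave open how a methyl, a methoxy or a fluoro group at the trifluoromethyl position would compare. They also leave open what an amine or a carboxylic acid in place of the chloro group would give.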